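This account rests on a few compounds, and the source may have more. Where it says the series, first, only, none or still open, it means among the compounds named here.

Series on the shared core, followed in a functional assay on HT cells (Homo sapiens) for antiproliferative activity, read by fluorescence, with a stated time of 72 h; on this read-out higher numbers stand for weaker inhibition of growth and lower numbers for stronger inhibition of growth. Compound 1 `CC(O)CSc1nc(NCc2ccc(-c3ccccn3)cc2)c2[nH]nc(C(C)C)c2n1` gives 62 nM; compound 2 `CC(C)c1n[nH]c2c(NCc3ccc(-c4ccccn4)cc3)nc(SC(C)C(C)O)nc12` gives 190 nM; compound 3 `CC(C)c1n[nH]c2c(NCc3ccc(-c4ccccn4)cc3)nc(SCCNC(=N)N)nc12` gives 390 nM. Compound 2 thus stands second highest of the three numbers: a 2.1-fold higher number from compound 2 to compound 3 (0.31 log units; beyond the scatter), and a 3.1-fold higher number from compound 1 to compound 2 (0.49 log units; beyond the scatter). Compound 4 `C=CCSc1nc(NCc2ccc(-c3ccccn3)cc2)c2[nH]nc(C(C)C)c2n1` is not yet measured; against compound 2 the change is allyl in place of 2-hydroxy-1-methylpropyl on a sulfur. Among the compounds with values here, the bearing step is a 3.1-fold higher number from compound 1 to compound 2 (0.49 log units; beyond the scatter), a modest rise on adding the methyl, so taking it away should move the other way; no measured step tests loss of the hydroxyl, and the allyl double bond is untested. The expected step is a 2.4-fold lower number from compound 2 to compound 4 (0.38 log units; beyond the scatter). Compound 4 is estimated at 80 nM, range 30 nM to 250 nM.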

Compound 4, concentration for 50% growth inhibition: 1010 nM
The estimate for compound 4 lay 13-fold (1.10 log units) below the measured number; the measured number lies above the stated range.
By their numbers in this assay, from the lowest: compound 1; then compound 2; then compound 3; then compound 4.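

Allyl on the sulfur gives the highest number so far in this assay: a 5.3-fold higher number from compound 2 to compound 4 (0.73 log units; beyond the scatter) and a 2.6-fold higher number from compound 3 to compound 4 (0.41 log units; beyond the scatter) and, as a large step, a 16-fold higher number from compound 1 to compound 4 (1.21 log units; beyond the scatter) in this series. Losing the methyl therefore does not set the outcome at this position, since a smaller group can still sit far above compound 1. This change removes the hydroxyl and brings in the double bond together, and no measurement on hand accounts for the rise.

Open, on these data alone, is which of the two matters: a saturated propyl chain or 3-hydroxypropyl on the sulfur would separate them. As far as these compounds go, a carboxylic acid on the same chain also remains open.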